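Swapping Bromo for Methyl on the Amide Phenyl

A few compounds are considered here, and "the series" means these few. Any claim that something is new, unique, unknown or untested is made for them only; others in the source may bear on it.

Compound 1 `O=C(Nc1cccc(/C=C/C(=O)c2nc3ccccc3[nH]2)c1)c1cccc(Cl)c1` gives 7840 nM in a functional assay on MCF7 cells (Homo sapiens) for antiproliferative activity, read by MTT assay, with a stated time of 48 h; a higher number here means a weaker inhibitor, a lower number a stronger inhibitor.
Compound 2 `O=C(Nc1cccc(/C=C/C(=O)c2nc3ccccc3[nH]2)c1)c1ccc(Cl)cc1` gives 8410 nM in this assay.
Compound 3 `O=C(/C=C/c1cccc(NC(=O)c2ccccc2Br)c1)c1nc2ccccc2[nH]1` gives 4520 nM in this assay.

Compound 3 shows the lowest of the three numbers, but its gaps to the other two are small: a 1.7-fold lower number from compound 1 to compound 3 (0.24 log units; within the scatter) and a 1.9-fold lower number from compound 2 to compound 3 (0.27 log units; within the scatter). Compound 4 `Cc1ccccc1C(=O)Nc1cccc(/C=C/C(=O)c2nc3ccccc3[nH]2)c1` differs from compound 3 in one place: methyl in place of bromo on an aromatic carbon. For the measured compounds named here, none of the measured steps makes this exact change; all three move a halogen around the same ring, and each stays within the scatter, as in a 1.1-fold higher number from compound 1 to compound 2 (0.03 log units; within the scatter). On that record the expected step in this assay is none beyond the scatter, a 1.1-fold higher number from compound 3 to compound 4 (0.04 log units; within the scatter). Compound 4 is accordingly estimated at 5000 nM, with a range from 2000 nM to 12500 nM.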

Compound 4, half-maximal inhibitory concentration: 5870 nM
Estimate against measurement, compound 4: 1.2-fold (0.07 log units) below, within the range that was stated.
By their numbers in this assay, from the lowest: compounds 3, 4, 1 and 2 (each within the scatter of the next).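

In this assay, a carbon group can take the place of the halogen on this ring without a change beyond the scatter (a 1.3-fold higher number from compound 3 to compound 4 (0.11 log units; within the scatter)). The comparisons with the two chlorine compounds stay within the scatter too (a 1.4-fold lower number from compound 2 to compound 4 (0.16 log units; within the scatter); a 1.3-fold lower number from compound 1 to compound 4 (0.13 log units; within the scatter)), so none of these four compounds stands apart from the others. No measurement shown gives a reason for this. The compounds shown leave open whether an amine or a carboxylic acid on this ring, or a longer chain in place of the methyl, would give a step beyond the scatter.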